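Series notes: heteroaryl swap on the unsaturated ring carbon

The source may report more compounds than this note shows. Statements on the series, on what has been measured and on what is new or still open speak of the compounds shown alone.

Two compounds of the series have numbers in an assay on CHO cells for displacement of a labelled ligand from Substance-P receptor (Homo sapiens), in the presence of a further agent that is not named here; a lower number here means a stronger inhibitor, a higher number a weaker inhibitor. Compound 1 `C[C@@H](O[C@H]1CN2C(=O)C=C(c3ccccc3)CC2[C@@H]1c1ccc(F)cc1)c1cc(C(F)(F)F)cc(C(F)(F)F)c1` gives 89.5 nM. Among the compounds with values here, compound 2 `C[C@@H](O[C@H]1CN2C(=O)C=C(c3cc[nH]c(=O)c3)CC2[C@@H]1c1ccc(F)cc1)c1cc(C(F)(F)F)cc(C(F)(F)F)c1` gives 3.9 nM, the lowest of the two numbers; its only neighbour is compound 1, and the step of a 23-fold lower number from compound 1 to compound 2 (1.36 log units; beyond the scatter) shows how much the group on the double-bonded ring carbon matters.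

Compound 3 `CCc1noc(C2=CC(=O)N3C[C@H](O[C@H](C)c4cc(C(F)(F)F)cc(C(F)(F)F)c4)[C@@H](c4ccc(F)cc4)C3C2)n1` differs from compound 2 in a single place: a group of 7 heavy atoms (4 carbon, 2 nitrogen, 1 oxygen; one five-membered aromatic ring with 3 hetero atoms) in place of a group of 7 heavy atoms (5 carbon, 1 nitrogen, 1 oxygen; one six-membered aromatic ring with 1 hetero atom), on a double-bonded ring carbon. Within the data shown here, no measured step covers an exchange of one aromatic ring for another at this position; the one known step, a 23-fold lower number from compound 1 to compound 2 (1.36 log units; beyond the scatter), replaced a carbon-only ring by a ring with a hydrogen-bond donor and acceptor, and compound 3 keeps acceptors but loses the donor. That step bears on the present one only in showing that the size of change available here is large. A worsening beyond the scatter is expected, yet the compound is expected to remain stronger than compound 1, so the estimated step is a 5.1-fold higher number from compound 2 to compound 3 (0.71 log units; beyond the scatter). For compound 3 the estimate in this assay is 20 nM, with a range from 4 nM to 100 nM.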

Compound 3, half-maximal inhibitory concentration: 27 nM
The estimate for compound 3 lay 1.4-fold (0.13 log units) below the measured number; the range from low to high includes it.
By their numbers in this assay, from the lowest: compound 2; then compound 3; then compound 1.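

In this assay, the 3-ethyl-1,2,4-oxadiazol-5-yl group, which has no hydrogen-bond donor, still gives a 3.3-fold lower number from compound 1 to compound 3 (0.52 log units; beyond the scatter) in exchange for phenyl, so at this double-bonded ring carbon an improvement on phenyl does not depend on a donor in the entering group. Within the data shown here, the size of that gain is limited, however: a 6.9-fold higher number from compound 2 to compound 3 (0.84 log units; beyond the scatter) shows that the position separates two aromatic groups with the same heavy-atom count, and the six-membered ring of compound 2 gives the lowest number of the series so far. No available evidence bears on what underlies either step.

The exchange from compound 2 to compound 3 alters ring size, hetero atoms, donor count and the ethyl substituent together, so these compounds cannot assign the step to any one of these differences. Open questions are how the number would respond to a plain pyridine ring without the carbonyl, which would test the ring of compound 2 more directly, and to an oxadiazole carrying an amine or a longer alkyl chain in place of ethyl.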